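Triazole-linked furanone series: benzyl versus phenyl on the triazole

The compounds below may be only part of what the source reports. "The series", "measured", "known", "first", "only" and "open" are said of these compounds alone.

Measured so far in a functional assay on MCF7 cells (Homo sapiens) for antiproliferative activity, read by MTT assay, with a stated time of 24 h; on this read-out lower numbers stand for stronger inhibition and higher numbers for weaker inhibition:
Compound 1 `O=C1O/C(=C\Cn2cc(Cc3ccccc3)nn2)C(OCc2ccccc2)=C1OCc1ccccc1` gives 40000 nM.
Compound 2 `O=C1NC(O)(CCn2cc(-c3ccccc3)nn2)C(OCc2ccccc2)=C1OCc1ccccc1` gives 20500 nM.

Among the compounds with values here, compound 2 and compound 1 differ in more than one place, so no single step between them is defined; their two numbers sit within the scatter of each other, and nothing separates compound 2 from compound 1 on what has been measured.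

Compound 3 `O=C1NC(O)(CCn2cc(Cc3ccccc3)nn2)C(OCc2ccccc2)=C1OCc1ccccc1`, not yet measured, follows from compound 2 by one change: benzyl in place of phenyl on an aromatic carbon. Within the data shown here, no measured pair isolates this change. Among the measured compounds shown here, with only two measured numbers, both within scatter of each other, the expected step from compound 2 to compound 3 is a 1.2-fold higher number from compound 2 to compound 3 (0.09 log units; within the scatter), no change beyond the scatter in either direction. Compound 3 is estimated at 25000 nM, with a range from 10000 nM to 60000 nM.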

Compound 3, half-maximal inhibitory concentration: 39200 nM
For compound 3 the middle estimate is 1.6-fold (0.20 log units) below the measured one; the range from low to high includes it.
By their numbers in this assay, from the lowest: compounds 2, 3 and 1 (each within the scatter of the next).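

In this assay, the series now has its first comparison that differs in one place: benzyl in place of phenyl on an aromatic carbon gives a 1.9-fold higher number from compound 2 to compound 3 (0.28 log units; within the scatter). On the core shared by these two compounds, 4-phenyl-1H-1,2,3-triazol-1-yl and 4-benzyl-1H-1,2,3-triazol-1-yl are therefore not separated at this position, so the change has no readable effect on this read-out. No supporting data bear on this result, and it remains a single pair on a single core.

Still open, going by these compounds, is whether an amine, a carboxylic acid or a longer chain on this aromatic carbon would give a step beyond the scatter. Also open, on these data alone, is whether the same exchange of phenyl and benzyl would read alike on the core of compound 1.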